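An Isopropyl Swap on the Aromatic Nitrogen

A few compounds are considered here, and "the series" means these few. Any claim that something is new, unique, unknown or untested is made for them only; others in the source may bear on it.

In a functional assay on FaDu cells (Homo sapiens) for cytotoxicity, read by MTT assay, with a stated time of 72 h (on this read-out lower numbers stand for higher toxicity in this test and higher numbers for lower toxicity in this test), compound 1 (`COc1ccc(NC(=O)C(=O)c2cn(C(C)C)c3ccccc23)cc1`) gives 181 nM and compound 2 (`COCCn1cc(C(=O)C(=O)Nc2ccc(OC(F)(F)F)cc2)c2ccccc21`) gives 487 nM as the higher of the two numbers, a gap beyond the scatter. Compound 3 (`CC(C)n1cc(C(=O)C(=O)Nc2ccc(OC(F)(F)F)cc2)c2ccccc21`) carries isopropyl in place of 2-methoxyethyl on an aromatic nitrogen. Among the compounds with values here, no measured pair shows this change alone, as compound 1 and compound 2 also differ in a second place. Compound 1, which also bears isopropyl, gives 181 nM as the lower number, so a modest step towards lower numbers is expected in this assay. The estimated step is a 1.8-fold lower number from compound 2 to compound 3 (0.26 log units; within the scatter) and remains uncertain. For compound 3 the expected value is 270 nM within an estimated range of 120 nM to 550 nM in this test.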

Compound 3, concentration lethal to 50% of the cells: 8930 nM
Estimate against measurement, compound 3: 33-fold (1.52 log units) below, and the stated range ends below it.
By their numbers in this assay, from the lowest: compound 1; then compound 2; then compound 3.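

At the aromatic nitrogen, with trifluoromethyl on the oxygen, isopropyl in place of 2-methoxyethyl proves a large change in this assay (an 18-fold higher number from compound 2 to compound 3 (1.26 log units; beyond the scatter)). With isopropyl held fixed, trifluoromethyl in place of methyl on that oxygen is also large (a 49-fold higher number from compound 1 to compound 3 (1.69 log units; beyond the scatter)). Among these three compounds, isopropyl therefore goes with the lowest number only alongside methyl on the oxygen, and no measurement shown accounts for either step.

As far as these compounds go, whether 2-methoxyethyl would have the same effect alongside methyl on that oxygen remains open. So does how an amine or a longer chain on this nitrogen would read.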